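Weak growth inhibitors: swapping the amide aryl group

This account rests on a few compounds, and the source may have more. Where it says the series, first, only, none or still open, it means among the compounds named here.

Compound 1 `Cc1cccc(NC(=O)COc2ccc(/C=C3\SC(=O)NC3=O)cc2)n1`: 58300 nM
Compound 2 `O=C(COc1ccc(/C=C2\SC(=O)NC2=O)cc1)Nc1cccc([N+](=O)[O-])c1`: > 100000 nM

Compound 1 has a 6-methylpyridin-2-yl group on the amide-type nitrogen of the shared core, and in a functional assay on PC-3 cells (Homo sapiens) for inhibition (on this read-out higher numbers stand for weaker inhibition of growth and lower numbers for stronger inhibition of growth), compound 1 gives 58300 nM. Compound 2 carries a 3-nitrophenyl group in that place. In this assay compound 2 gives only a limit of the assay, > 100000 nM, and so no number. Among the compounds with values here, the one measured step, an at least 1.7-fold higher number from compound 1 to compound 2 (0.23 log units; that floor lies within the scatter), is the sole comparison available; its floor rests on (the limit of > 100000 nM in this assay, at which 1 of the 2 values shown sits). Compound 3 `O=C(COc1ccc(/C=C2\SC(=O)NC2=O)cc1)Nc1ccc(F)cc1` differs from compound 2 by 4-fluorophenyl in place of 3-nitrophenyl on an amide-type nitrogen. Within the data shown here, no measured step mirrors this change, so the size expected for an at least 1.4-fold lower number from compound 2 to compound 3 (0.15 log units; that floor lies within the scatter) is uncertain and no direction beyond the scatter can be claimed. Compound 3 is therefore expected to sit near 70000 nM, with a range from 25000 nM to 200000 nM, and a number may again not be reached.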

Compound 3, concentration for 50% growth inhibition: > 100000 nM
Compound 3 ended at the assay's limit; the forecaster's own chance of this, stated with the estimate: 40%; middle value at least 1.4-fold (0.15 log units) from the limit.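

In this assay, 4-fluorophenyl on the amide-type nitrogen leaves the read-out at a limit of the assay, as 3-nitrophenyl did, so two different substituted phenyl groups in this place have now given no number: the limit of > 100000 nM in this assay, at which 2 of the 3 values shown sit. The step between compound 2 and compound 3 cannot be read, as both values are limits, and nothing can be said about how the fluorine and nitro substituents compare. With 4-fluorophenyl in place of 6-methylpyridin-2-yl, the reading is an at least 1.7-fold higher number from compound 1 to compound 3 (0.23 log units; that floor lies within the scatter), which gives only a floor inside the scatter, so no order among the three groups can be claimed.

The compounds shown leave open whether any group at this nitrogen gives clearly stronger inhibition of growth than the value for compound 1. A phenyl group carrying an amine or a carboxylic acid, or a longer chain in place of the aromatic ring, might yet settle that.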